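From Trifluorophenyl to Fluoronitrophenyl: Predicting Compound 4

The source may hold more compounds than are shown below. What is called first, only, known or untested is meant among the compounds shown, and "the series" means these compounds.

Compound 1 `CC(C)[C@H](NC(=O)COc1cccc2ccccc12)C(=O)N[C@@H](CC(=O)O)C(=O)COc1ccc(-c2ccccc2)cc1`: 87900 nM
Compound 2 `CC(C)[C@H](NC(=O)COc1cccc2ccccc12)C(=O)N[C@@H](CC(=O)O)C(=O)COc1c(F)ccc(F)c1F`: 1200 nM
Compound 3 `CC(C)[C@H](NC(=O)COc1cccc2ccccc12)C(=O)N[C@@H](CC(=O)O)C(=O)COc1c(F)cc(F)cc1F`: 6840 nM

In a functional assay on Jurkat cells (Homo sapiens) (a higher number here means a weaker inhibitor, a lower number a stronger inhibitor), compound 3 stands in the middle of the three numbers, with compound 2 lower and compound 1 higher. The next compound, compound 4 `CC(C)[C@H](NC(=O)COc1cccc2ccccc12)C(=O)N[C@@H](CC(=O)O)C(=O)COc1ccc([N+](=O)[O-])cc1F`, keeps the shared core and places 2-fluoro-4-nitrophenyl in place of 2,4,6-trifluorophenyl on an oxygen on a saturated carbon.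

For the measured compounds named here, no measured compound carries a nitro group, so the steps offer only indirect guidance. Two trifluorophenyl groups already differ, with a 5.7-fold higher number from compound 2 to compound 3 (0.76 log units; beyond the scatter). Replacing 4-phenylphenyl has a larger effect, with a 13-fold lower number from compound 1 to compound 3 (1.11 log units; beyond the scatter) and a 73-fold lower number from compound 1 to compound 2 (1.86 log units; beyond the scatter). Going by the values given here, compound 1, the only measured compound without fluorine, has the highest number, 87900 nM. Compound 4 keeps some fluorine but less than compound 3, so a modest rise is expected in this assay, though this rests on very few compounds. The expected step is a 2.2-fold higher number from compound 3 to compound 4 (0.34 log units; beyond the scatter). The estimate for compound 4 is 15000 nM, with an expected range of 3000 nM to 60000 nM.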

Compound 4, half-maximal inhibitory concentration: 30300 nM
Compound 4: the middle estimate sits 2.0-fold (0.31 log units) below what was measured; the measured number falls inside the stated range.
By their numbers in this assay, from the lowest: compound 2; then compound 3; then compound 4; then compound 1.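

In this assay, 2-fluoro-4-nitrophenyl in place of 2,4,6-trifluorophenyl gives a 4.4-fold higher number from compound 3 to compound 4 (0.65 log units; beyond the scatter) and in place of 2,3,6-trifluorophenyl gives a 25-fold higher number from compound 2 to compound 4 (1.40 log units; beyond the scatter), so a ring with a nitro group and one fluorine falls behind both trifluorophenyl rings at this position on the oxygen. The same group in place of 4-phenylphenyl still gives a 2.9-fold lower number from compound 1 to compound 4 (0.46 log units; beyond the scatter), which places this first ring carrying nitrogen and oxygen atoms between the trifluorophenyl compounds and compound 1. Nothing measured here explains this order.

Compound 4 differs from compound 3 both in its number of fluorines and in its nitro group, and the compounds shown cannot separate these two changes. Also open, from the compounds shown here alone, is how a ring would behave with a nitrile or an amine in place of the nitro group.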